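A Longer Amide Chain on a Limit-Bound Core

The compounds below may be only part of what the source reports. "The series", "measured", "known", "first", "only" and "open" are said of these compounds alone.

In a physicochemical assay for solubility (on this read-out higher numbers stand for higher solubility and lower numbers for lower solubility), compound 1 (`CNC(=O)c1cc(C(=O)NC)c(=O)n(Cc2ccccc2)c1`) gives >= 118 ug/mL, which is a limit. Compound 2 (`CNC(=O)c1ccc(=O)n(Cc2ccccc2)c1`) gives >= 108 ug/mL, which is also a limit. Compound 3 (`CNC(=O)c1cc(C(=O)NCCC(C)C)cn(Cc2ccccc2)c1=O`) differs from compound 1 by a change at one amide: isobutyl in place of hydrogen on a saturated chain carbon bound to an amide-type nitrogen. Within the data shown here, the only measured step is a step that the two limits leave unreadable from compound 1 to compound 2, and it sets no size for this change, so only a modest fall in this assay is expected, resting on the structural change alone. The expected step is an at least 1.4-fold lower number from compound 1 to compound 3 (0.16 log units; that floor lies within the scatter). Compound 3 is estimated at 80 ug/mL, with an expected range between 20 ug/mL and 150 ug/mL.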

Compound 3, solubility: 10 ug/mL
Estimate against measurement, compound 3: 8.0-fold (0.90 log units) above, outside the stated range (below it).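

Among these compounds, at this amide, going from methylcarbamoyl to isopentylcarbamoyl gives the one readable step in this assay, an at least 11-fold lower number from compound 1 to compound 3 (1.07 log units; beyond the scatter). The earlier step, with hydrogen in place of methylcarbamoyl on an aromatic carbon, cannot be read, so this is the first size shown for any change on the shared core. Compound 1 stands at a limit, so the size printed for this step is a floor: the limit of >= 118 ug/mL in this assay, at which 1 of the 3 values shown sits.

The compounds shown leave open how the number moves with an ethyl chain, a longer chain, or a chain ending in an amine or a carboxylic acid at this amide. They also leave open whether the same change at the other methylcarbamoyl gives a step of similar size.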